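Carboxymethyl to 1-carboxy-1-methylethyl: next step in the series

The compounds below may be only part of what the source reports. "The series", "measured", "known", "first", "only" and "open" are said of these compounds alone.

In a functional assay on the whole organism for inhibition, with Cavia porcellus as the target (on this read-out higher numbers stand for an effect only at larger amounts of compound and lower numbers for an effect already at smaller amounts), compound 1 (`CCCC(=O)CC(=O)N1CCSC1COc1ccccc1OC`) gives 42 mg/kg and compound 2 (`COc1ccccc1OCC1SCCN1C(=O)CC(=O)O`) gives 20 mg/kg as the lower of the two numbers. Compound 3 (`COc1ccccc1OCC1SCCN1C(=O)C(C)(C)C(=O)O`) carries 1-carboxy-1-methylethyl in place of carboxymethyl on a carbonyl carbon. Within the data shown here, the only measured step, a 2.1-fold lower number from compound 1 to compound 2 (0.32 log units; beyond the scatter), is modest and concerns a different change, hydroxy in place of propyl on a carbonyl carbon. Among the measured compounds shown here, no measured step covers the present change, so no shift beyond the scatter is expected in this assay. The expected step is no change at the digits printed from compound 2 to compound 3 (within the scatter). For compound 3 the estimated value is 20 mg/kg with 8 mg/kg to 50 mg/kg as its range.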

Compound 3, dose for half-maximal effect: 34 mg/kg
Estimate against measurement, compound 3: 1.7-fold (0.23 log units) below; measured number inside the range.
By their numbers in this assay, from the lowest: compounds 2, 3 and 1 (each within the scatter of the next, the first and the last beyond it).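

On the carbonyl carbon bound to the amide-type ring nitrogen, 1-carboxy-1-methylethyl is tolerated in place of carboxymethyl in this assay: the result is a 1.7-fold higher number from compound 2 to compound 3 (0.23 log units; within the scatter) and does not separate the two groups. Against (propylcarbonyl)methyl the result is a 1.2-fold lower number from compound 1 to compound 3 (0.09 log units; within the scatter), so compound 3 separates from neither neighbour, although compound 1 and compound 2 lie beyond the scatter of each other. Nothing available explains these readings.

Open, on these data alone, is how an amine or a longer chain ending in the carboxy group would read at this carbonyl carbon in this assay.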